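The compounds below may be only part of what the source reports. "The series", "measured", "known", "first", "only" and "open" are said of these compounds alone.

Measured compounds and their values:

- compound 1, `Cc1cc(Oc2ccc(-c3ccn(CC4CCC4)c(=O)c3C#N)cc2)ccn1`, gives 126 nM
- compound 2, `CCCCn1ccc(-c2ccc(Oc3ccnc(C)c3)cc2)c(C#N)c1=O`, gives 398 nM
- compound 3, `CCCCn1ccc(-c2ccc(Oc3ccnc(C)c3)c(Cl)c2)c(C#N)c1=O`, gives 166 nM

All three were tested in a functional assay on CHO cells for positive allosteric modulation of metabotropic glutamate receptor 2 (Homo sapiens), read by scintillation counting and GTPgammaS binding, with a stated time of 30 min; a lower number here means that less compound is needed, a higher number that more compound is needed for the effect. Among them compound 2 has the highest number: compound 3 lies closest, and compound 1 furthest away, as the two measured steps show. The step of a 3.2-fold higher number from compound 1 to compound 2 (0.50 log units; beyond the scatter) came with a propyl in place of cyclobutyl on a saturated chain carbon bound to an aromatic nitrogen; the step of a 2.4-fold lower number from compound 2 to compound 3 (0.38 log units; beyond the scatter) came with a chloro in place of hydrogen on an aromatic carbon.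

Compound 4, `CCCCn1ccc(-c2ccc(Oc3ccnc(C)c3)cc2Cl)c(C#N)c1=O`, has not yet been measured. It differs from compound 2 by chloro in place of hydrogen on an aromatic carbon, placed on an aromatic carbon of a six-membered aromatic ring of carbon only, ortho to a large group and meta to the (2-methylpyridin-4-yl)oxy group. Among the measured compounds shown here, the only step that bears on this is a 2.4-fold lower number from compound 2 to compound 3 (0.38 log units; beyond the scatter), where a chloro entered the same ring but at a different carbon. Going by these compounds, whether the new position behaves the same is unknown, so only a modest step is expected, if any: the estimated step is a 1.4-fold lower number from compound 2 to compound 4 (0.15 log units; within the scatter), and compound 4 is expected to give 280 nM, with a range from 100 nM to 800 nM.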

Compound 4, half-maximal effective concentration: 933 nM
Compound 4: middle estimate off by 3.3-fold (0.52 log units), on the low side; the measured number lies above the stated range.
By their numbers in this assay, from the lowest: compounds 1 and 3 (each within the scatter of the next); then compound 2; then compound 4.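

Placed ortho to a large group and meta to the (2-methylpyridin-4-yl)oxy group, the chloro gives a step in this assay that runs the opposite way (a 2.3-fold higher number from compound 2 to compound 4 (0.37 log units; beyond the scatter)) from the step seen when a chloro entered the same ring at the other carbon (a 2.4-fold lower number from compound 2 to compound 3 (0.38 log units; beyond the scatter)). Adding this one atom therefore has no single direction of effect on this ring: the outcome depends on which carbon carries it. No measurement shown here explains why the two carbons differ.

Going by these compounds, whether a fluoro or a methoxy group on this same carbon would also raise the number remains open. So does whether a chloro here would give a similar step on the core of compound 1, which carries the cyclobutyl group.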